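Phenylsulfonyl replaces the aminopyridine carbonyl on the ring amine

A few compounds are considered here, and "the series" means these few. Any claim that something is new, unique, unknown or untested is made for them only; others in the source may bear on it.

Compound 1 `O=C(c1ccc(C(F)(F)F)cc1)N1CCC(NS(=O)(=O)c2cc(S(=O)(=O)c3ccccc3)ccc2C(F)(F)F)CC1` and compound 2 `CN(C)c1ccc(C(=O)N2CCC(NS(=O)(=O)c3cc(S(=O)(=O)c4ccccc4)ccc3C(F)(F)F)CC2)cn1` share a core and differ only in the group on the carbonyl carbon. For the measured compounds named here, in an assay on U2OS cells for inhibition of secreted frizzled-related protein 1 (Homo sapiens), read by a luciferase reporter, with a stated time of 18 h (on this read-out higher numbers stand for an effect only at larger amounts of compound and lower numbers for an effect already at smaller amounts), compound 1 gives 970 nM and compound 2 gives 70 nM, so that compound 2 stands at the lowest of the two numbers known, with a 14-fold lower number from compound 1 to compound 2 (1.14 log units; beyond the scatter) as the step between them. Compound 3 `O=S(=O)(NC1CCN(S(=O)(=O)c2ccccc2)CC1)c1cc(S(=O)(=O)c2ccccc2)ccc1C(F)(F)F` carries a different change: phenylsulfonyl in place of (6-(dimethylamino)pyridin-3-yl)carbonyl on an amine nitrogen in a ring. Going by the values given here, only the step from compound 1 to compound 2 bears on it, and that step was large, showing that the group on the ring amine matters strongly. Because compound 2 gives 70 nM after the gain of the dimethylamino-pyridine carbonyl, and that group now leaves, compound 3 is expected to give a higher number, near compound 1. The step from compound 2 to compound 3 is estimated as an 11-fold higher number from compound 2 to compound 3 (1.06 log units; beyond the scatter). Compound 3 is therefore estimated at 800 nM, within 200 nM to 4000 nM.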

Compound 3, half-maximal effective concentration: 210 nM
Beside the measured number, compound 3's estimate is 3.8-fold (0.58 log units) above it; low and high end bracket the measured number.
By their numbers in this assay, from the lowest: compound 2; then compound 3; then compound 1.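

Phenylsulfonyl on the amine nitrogen of the six-membered ring shows that this position does not need a carbonyl in this assay. In place of (6-(dimethylamino)pyridin-3-yl)carbonyl it gives a 3.0-fold higher number from compound 2 to compound 3 (0.48 log units; beyond the scatter), and in place of (4-(trifluoromethyl)phenyl)carbonyl it gives a 4.6-fold lower number from compound 1 to compound 3 (0.66 log units; beyond the scatter), so the sulfonyl compound falls between the two carbonyl compounds, and the change from carbonyl to sulfonyl is not tied to a single direction. Nothing available accounts for either step.

The compounds shown leave open whether a dimethylamino group on the ring attached to the sulfonyl would bring the same gain as it does in compound 2, as in a 6-(dimethylamino)pyridin-3-ylsulfonyl group. They also leave open how a methylsulfonyl group, with no aromatic ring, or a urea would fare on this nitrogen.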